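The compounds below may be only part of what the source reports. "The series", "measured", "known", "first", "only" and "open" are said of these compounds alone.

Of the compounds shown here, three have so far been tested in a toxicity assay on THP-1 cells (Homo sapiens) for inhibition (on this read-out lower numbers stand for higher toxicity in this test and higher numbers for lower toxicity in this test), and every one of them sits at the limit of the assay. Compound 1 `CCCCn1c(-c2ccc(OC)cc2)cnc1NC(=O)c1ccc(F)cc1` gives > 100000 nM, which is a limit rather than a measured number. Compound 2 `COc1ccc(-c2cnc(NC(=O)c3cccc(OC)c3)n2C)cc1` gives > 100000 nM, again a limit. Compound 3 `COc1ccc(-c2cnc(NC(=O)c3cccnc3)n2C)cc1` gives > 100000 nM, also a limit. Between the last two lies a step that the two limits leave unreadable from compound 2 to compound 3. Compound 4 `COc1ccc(-c2cnc(NC(=O)c3ccn[nH]3)n2C)cc1` differs from compound 3 by 1H-pyrazol-5-yl in place of pyridin-3-yl on a carbonyl carbon. Among the compounds with values here, no measured step has a readable size, and all values sit at the limit of > 100000 nM in this assay, at which 3 of the 3 values shown sit, so no step beyond the scatter is expected in this assay from compound 3 to compound 4. Compound 4 is expected to give about 150000 nM, between 60000 nM and 500000 nM, most likely again reported as a limit. The expected step is a step that the limit leaves unreadable from compound 3 to compound 4.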

Compound 4, half-maximal cytotoxic concentration: > 100000 nM
Compound 4: no number, only a limit; the forecaster's own chance of this, stated with the estimate: 85%; the middle value does not contradict the limit.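

Within the data shown here, compound 2, compound 3 and compound 4 all sit at a limit, so no step between them can be read in this assay: the limit of > 100000 nM in this assay, at which 4 of the 4 values shown sit. The compounds shown leave open whether the group on the carbonyl carbon affects toxicity at all.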